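What one added chloro may do to compound 2

The source may report more compounds than this note shows. Statements on the series, on what has been measured and on what is new or still open speak of the compounds shown alone.

In a functional assay on MDA-MB-231 cells (Homo sapiens) for antiproliferative activity, read by sulforhodamine B assay, with a stated time of 72 h (on this read-out lower numbers stand for stronger inhibition and higher numbers for weaker inhibition), compound 1 `FC(F)(F)c1ccc(/C=C\c2cc3ccccc3nc2Cl)cc1` gives 5360 nM and compound 2 `Fc1ccc(/C=C\c2cc3ccccc3nc2Cl)cc1` gives 24000 nM, the higher of these two numbers. Compound 3 `Fc1ccc(/C=C/c2cc3ccccc3nc2Cl)cc1` is reported only as a limit, > 50000 nM.

Compound 4 `Fc1ccc(/C=C\c2cc3ccc(Cl)cc3nc2Cl)cc1` has one change from compound 2: chloro in place of hydrogen on an aromatic carbon. Among the measured compounds shown here, no measured step involves that place. The an at least 2.0-fold higher number from compound 2 to compound 3 (0.31 log units; beyond the scatter) concerns only the double bond, which compound 4 keeps as drawn in compound 2. The nearest guide is therefore a 4.5-fold higher number from compound 1 to compound 2 (0.65 log units; beyond the scatter), where trifluoromethyl gave way to fluoro. It suggests, weakly, that adding a halogen could lower the number modestly.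

The expected change is a 2.0-fold lower number from compound 2 to compound 4 (0.30 log units; within the scatter). Compound 4 is estimated at 12000 nM, with an expected range of 4000 nM to 40000 nM.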

Compound 4, half-maximal inhibitory concentration: 42600 nM
Estimate against measurement, compound 4: 3.6-fold (0.55 log units) below, and the stated range ends below it.
By their numbers in this assay, from the lowest: compound 1; then compounds 2 and 4 (each within the scatter of the next). At a limit, above all of these: compound 3.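

Chloro in place of hydrogen on this aromatic carbon gives a 1.8-fold higher number from compound 2 to compound 4 (0.25 log units; within the scatter), so compound 2 and compound 4 cannot be told apart in this assay. Among the compounds shown here, the earlier steps concerned only the swap of trifluoromethyl for fluoro and the double bond, so this is the first reading from this place on the shared core. Nothing shown here accounts for the result.

On these data alone, whether an amine or a carboxylic acid at this place would stand apart from hydrogen remains open. So does whether chloro here would behave the same alongside the trifluoromethyl of compound 1.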